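Amide head-group variation on the shared core

A few compounds are considered here, and "the series" means these few. Any claim that something is new, unique, unknown or untested is made for them only; others in the source may bear on it.

The three measured compounds share one core and differ in the group on the saturated chain carbon bound to the carbonyl carbon and in the substituent on the far side of the core. Compound 1 `C[C@@H]1CN(c2sc(C(F)(F)F)nc2-c2nc3cc(OCCO)ccc3[nH]2)CCN1C(=O)Cn1cnc2cccnc21` in a functional assay on Venous blood for antagonist activity at C-X-C chemokine receptor type 3 (Homo sapiens), read by flow cytometry, with a stated time of 30 min, in the presence of a further agent that is not named here (a higher number here means a weaker inhibitor, a lower number a stronger inhibitor), gives 99.1 nM. Compound 3 `Cc1nc(C)n(CC(=O)N2CCN(c3sc(C(F)(F)F)nc3-c3nc4ccc(C5CCOCC5)cc4[nH]3)C[C@H]2C)n1` in this assay gives 123 nM. Compound 2 `C[C@@H]1CN(c2sc(C(F)(F)F)nc2-c2nc3ccccc3[nH]2)CCN1C(=O)Cn1cccn1` in this assay gives 191 nM; this is the highest of the three numbers, yet its gap to compound 3 and its gap to compound 1 both lie within the usual scatter, so the three compounds are not separated by these measurements.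

Compound 4 `Cc1nn(CC(=O)N2CCN(c3sc(C(F)(F)F)nc3-c3nc4ccccc4[nH]3)C[C@H]2C)cc1CN(C)C` differs from compound 2 in one place: 4-((dimethylamino)methyl)-3-methyl-1H-pyrazol-1-yl in place of 1H-pyrazol-1-yl on a saturated chain carbon bound to a carbonyl carbon. Among the measured compounds shown here, no pair of measured compounds differs in only one place, so no measured step is available to anchor this change, and the other two head groups in the set give numbers close to that of compound 2.

The step from compound 2 to compound 4 is expected to be a 1.6-fold lower number from compound 2 to compound 4 (0.20 log units; within the scatter), a slightly lower number that does not go beyond the scatter. Compound 4 is estimated at 120 nM, with a range from 40 nM to 350 nM.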

Compound 4, half-maximal inhibitory concentration: 330 nM
The estimate for compound 4 lay 2.8-fold (0.44 log units) below the measured number; low and high end bracket the measured number.
By their numbers in this assay, from the lowest: compounds 1, 3, 2 and 4 (each within the scatter of the next, the first and the last beyond it).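

Among the compounds shown here, compound 4 gives the first single-place step in this set, and it falls on the group on a saturated chain carbon bound to a carbonyl carbon: in this assay, 4-((dimethylamino)methyl)-3-methyl-1H-pyrazol-1-yl in place of 1H-pyrazol-1-yl gives a 1.7-fold higher number from compound 2 to compound 4 (0.24 log units; within the scatter), so this step does not separate the two compounds. The entering group has 10 heavy atoms against 5 and one more hydrogen-bond acceptor, and the same five-membered aromatic ring is kept, so at this position, on the unsubstituted far side of the core shared by compound 2 and compound 4, this enlargement of the head group leaves the number within the scatter. No supporting measurement is available that could account for this step or assign it to any feature of the entering group.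

The entering group adds a methyl and a dimethylaminomethyl together, so the contribution of each remains unresolved; 3-methyl-1H-pyrazol-1-yl alone and 4-((dimethylamino)methyl)-1H-pyrazol-1-yl alone would divide the step between them. Also open, as far as these compounds go, is how a carboxylic acid or a longer chain in place of the dimethylamino group would read, and whether the same change holds with the far-side substituents of compound 1 and compound 3.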